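The compounds below may be only part of what the source reports. "The series", "measured", "known", "first", "only" and "open" are said of these compounds alone.

Compound 1 `CCCc1nc(C)c2ccnc(Nc3cc[nH]n3)n12` gives 25000 nM in a functional assay for inhibition, with Homo sapiens as the target; a higher number here means a weaker inhibitor, a lower number a stronger inhibitor. Compound 2 `CCCc1nc(C)c2c(CC)cnc(Nc3cc[nH]n3)n12` gives in this assay only a limit, > 48000 nM. The change between them, (ethyl in place of hydrogen on an aromatic carbon), yields an at least 1.9-fold higher number from compound 1 to compound 2 (0.28 log units; that floor lies within the scatter). Compound 3 `Oc1nncc2cncn12` gives in this assay only a limit, > 48000 nM. The difference between the core of compound 3 and the core of compound 1 is not broken down here. Compound 4 `CCc1ncn2c(O)nncc12` is not yet measured and differs from compound 3 by ethyl in place of hydrogen on an aromatic carbon. This is the same kind of change as from compound 1 to compound 2, though the place differs: in compound 2 the ethyl sits on a six-membered aromatic ring with 2 nitrogen, ortho to a fused ring, whereas in compound 4 it sits on a five-membered aromatic ring with 2 nitrogen, next to the ring nitrogen. The step expected from compound 3 to compound 4 is a step that the limit leaves unreadable from compound 3 to compound 4, set beside an at least 1.9-fold higher number from compound 1 to compound 2 (0.28 log units; that floor lies within the scatter) and resting on (the limit of > 48000 nM in this assay, at which 2 of the 3 values shown sit). For compound 4 the estimated value in this assay is 70000 nM, most likely reported again as a limit.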

Compound 4, half-maximal inhibitory concentration: > 48000 nM
Compound 4: only a limit was reported; the forecaster's own chance of this, stated with the estimate: 90%; the middle value lies beyond the limit too.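

Compound 4 gives > 48000 nM in this assay, a limit, and compound 3 also gives only a limit, so no step can be read between compound 3 and compound 4. As far as these compounds go, whether ethyl in place of hydrogen changes inhibition on this core stays open.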